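Pyrrolidinyl amide for tert-butyl ester: expected cytotoxicity

The source may hold more compounds than are shown below. What is called first, only, known or untested is meant among the compounds shown, and "the series" means these compounds.

Within the data shown here, compound 1 `CC(C)(C)OC(=O)/C=C/c1ccc2c(c1)C(=O)C(=O)N2Cc1ccc(Br)cc1` gives the lowest number of the two measured so far in a functional assay on HT-29 cells (Homo sapiens) for cytotoxicity, read by MTT assay, with a stated time of 48 h (a lower number here means a stronger inhibitor, a higher number a weaker inhibitor), at 730 nM. Compound 2 `COC(=O)/C=C/c1ccc2c(c1)/C(=N/O)C(=O)N2Cc1ccc(Br)cc1` gives 3640 nM, a number beyond the scatter from compound 1. Among the measured compounds shown here, compound 3 `O=C1C(=O)N(Cc2ccc(Br)cc2)c2ccc(/C=C/C(=O)N3CCCC3)cc21` differs from compound 1 by pyrrolidin-1-yl in place of tert-butoxy on a carbonyl carbon; no measured pair shows a tert-butoxycarbonyl to (pyrrolidin-1-yl)carbonyl exchange on its own, so its step size is not known. In this assay the expected step is a 1.4-fold higher number from compound 1 to compound 3 (0.14 log units; within the scatter), probably within the scatter. Compound 3 is estimated at 1000 nM, with a range from 300 nM to 3500 nM.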

Compound 3, half-maximal inhibitory concentration: 4420 nM
The estimate for compound 3 lay 4.4-fold (0.65 log units) below the measured number; the whole stated range lies below it.
By their numbers in this assay, from the lowest: compound 1; then compounds 2 and 3 (each within the scatter of the next).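

Among these compounds, on a carbonyl carbon, pyrrolidin-1-yl in place of tert-butoxy is the first single-place change that can be read, and in this assay it gives a 6.1-fold higher number from compound 1 to compound 3 (0.78 log units; beyond the scatter). The group on this carbonyl carbon therefore matters to the cytotoxicity read-out, with the core of compound 1 otherwise unchanged. Nothing available explains the size of this step.

Going by these compounds, whether the step belongs to amides in general or to pyrrolidin-1-yl alone remains open. A diethylamino amide, a piperidin-1-yl amide or a carboxylic acid at this carbonyl carbon would help separate these readings.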